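From hydroxy to methoxy on compound 2

The source may hold more compounds than are shown below. What is called first, only, known or untested is meant among the compounds shown, and "the series" means these compounds.

In a functional assay on KBVIN cells (Homo sapiens) for antiproliferative activity, read by sulforhodamine B assay, with a stated time of 3 days (a lower number here means that less compound is needed, a higher number that more compound is needed for the effect), compound 1 `CCCCc1ccc(-c2cc(=O)c3c(o2)C(CC)(CC)C(=O)C(CC)=C3O)cc1` gives 37 uM and compound 2 `CCC1=C(O)c2c(oc(-c3ccc(O)cc3)cc2=O)C(CC)(CC)C1=O` gives 20.6 uM, so the two cannot be separated on these numbers. Compound 3 `CCC1=C(O)c2c(oc(-c3ccc(OC)cc3)cc2=O)C(CC)(CC)C1=O` differs from compound 2 by methyl in place of hydrogen on an oxygen on an aromatic ring, with methyl in place of hydrogen on an oxygen on an aromatic ring, hydroxy to methoxy. Within the data shown here, only one measured step bears on this, a 1.8-fold lower number from compound 1 to compound 2 (0.25 log units; within the scatter), with hydroxy in place of butyl on an aromatic carbon. The expected step is therefore small, a 1.2-fold higher number from compound 2 to compound 3 (0.08 log units; within the scatter), and none beyond the scatter in this assay. The estimated value for compound 3 is 25 uM, with an expected range from 12 uM to 50 uM.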

Compound 3, concentration for half-maximal effect: 0.68 uM
Estimate against measurement, compound 3: 37-fold (1.57 log units) above; the measured number lies below the stated range.
By their numbers in this assay, from the lowest: compound 3; then compounds 2 and 1 (each within the scatter of the next).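

In this assay, going from hydroxy to methoxy gives a 30-fold lower number from compound 2 to compound 3 (1.48 log units; beyond the scatter) and shows that this position responds strongly to a single added methyl, which the earlier step within the scatter did not reveal. Methoxy in place of butyl on the same aromatic carbon gives a 54-fold lower number from compound 1 to compound 3 (1.74 log units; beyond the scatter) as well, so among the three groups shown, only methoxy stands apart. No measurement here accounts for the size of these steps. On these data alone, whether the effect is specific to methoxy remains open. Ethoxy, a longer alkoxy chain or an amine at this place could settle that.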